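A few compounds are considered here, and "the series" means these few. Any claim that something is new, unique, unknown or untested is made for them only; others in the source may bear on it.

Compound 1 `Cc1ccc(S(=O)(=O)N2CCC(Br)CC2)cc1` carries only hydrogen at the saturated ring carbon next to the sulfonamide nitrogen. In a functional assay on WiDr cells (Homo sapiens) for antiproliferative activity, read by sulforhodamine B assay, with a stated time of 48 h (on this read-out lower numbers stand for stronger inhibition of growth and higher numbers for weaker inhibition of growth), compound 1 reaches only a limit of the assay, > 100000 nM, rather than a number. Compound 2 `Cc1ccc(S(=O)(=O)N2CC[C@@H](Br)C[C@@H]2CC(C)C)cc1` adds an isobutyl group there, and in this assay compound 2 gives 14000 nM. Within the data shown here, the step of an at least 7.1-fold lower number from compound 1 to compound 2 (0.85 log units; beyond the scatter) is the sole measured step, and compound 2 holds the only actual number in the set, since the other value is a limit (the limit of > 100000 nM in this assay, at which 1 of the 2 values shown sits). Compound 3 `CCCCCCC[C@H]1C[C@H](Br)CCN1S(=O)(=O)c1ccc(C)cc1` differs from compound 2 by hexyl in place of isopropyl on a saturated chain carbon bound to a saturated ring carbon. Among the measured compounds shown here, no measured step follows a change of chain length at that carbon; the step from compound 1 to compound 2 shows only that a chain at this position is tolerated. The step of a 1.4-fold lower number from compound 2 to compound 3 (0.15 log units; within the scatter) is therefore expected to stay within the scatter. Compound 3 is estimated at 10000 nM, with a range from 3000 nM to 40000 nM.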

Compound 3, concentration for 50% growth inhibition: > 100000 nM
Compound 3: a limit, no number; the forecaster's own chance of this, stated with the estimate: 10%; middle value at least 10-fold (1.00 log units) away from the limit.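

Lengthening the chain does not extend the gain seen with the isobutyl group: with hexyl in place of isopropyl on a saturated chain carbon bound to a saturated ring carbon, this assay shows an at least 7.1-fold higher number from compound 2 to compound 3 (0.85 log units; beyond the scatter). The earlier step showed only that a chain here can lower the number, whereas this one shows that the outcome depends on which chain is present, and that heptyl does not retain the effect of isobutyl. The step from compound 1 to compound 3 cannot be read, as both values are limits of the assay: the limit of > 100000 nM in this assay, at which 2 of the 3 values shown sit.

The compounds shown leave open where between isobutyl and heptyl the number is lost, as a pentyl chain might indicate, and whether the branch matters, as a straight butyl chain might indicate. They also leave open whether a chain ending in an amine or a carboxylic acid would give a number at this position.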